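What a Chloropyridine Might Do to Clearance

The source may hold more compounds than are shown below. What is called first, only, known or untested is meant among the compounds shown, and "the series" means these compounds.

In an in vitro ADME assay on microsomes from liver (Homo sapiens) for metabolic stability (on this read-out higher numbers stand for fast clearance and lower numbers for slow clearance), compound 1 (`O=C(COCc1ccccc1)N1CCN(c2ccc(F)cc2)CC1`) gives 110 mL.min-1.g-1, compound 2 (`O=C(COCc1ccccc1)N1CCN(c2ccc(Cl)cc2Cl)CC1`) gives 450 mL.min-1.g-1 and compound 3 (`O=C(COCc1ccccc1)N1CCN(c2ccc(F)cc2Cl)CC1`) gives 530 mL.min-1.g-1. Compound 3 thus sits at the fast-clearing top of this small set, but it shares that place, as the data show a 1.2-fold higher number from compound 2 to compound 3 (0.07 log units; within the scatter).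

Compound 4 (`O=C(COCc1ccccc1)N1CCN(c2cc(Cl)ccn2)CC1`) carries a larger change on an amine nitrogen in a ring: 4-chloropyridin-2-yl in place of 2-chloro-4-fluorophenyl on an amine nitrogen in a ring. In words, this is 4-chloropyridin-2-yl in place of 2-chloro-4-fluorophenyl.

The nearest evidence concerns chloro. The data show a 4.8-fold higher number from compound 1 to compound 3 (0.68 log units; beyond the scatter) and also a 4.1-fold higher number from compound 1 to compound 2 (0.61 log units; beyond the scatter), both modest steps. Among the measured compounds shown here, compound 4 keeps a chloro, yet no measured compound has an aromatic ring with a hetero atom, so that part of the change is untested.

A modest drop in this assay is therefore expected, and the expected step is a 2.7-fold lower number from compound 3 to compound 4 (0.42 log units; beyond the scatter). For compound 4 the estimate is 200 mL.min-1.g-1, with an expected range of 70 mL.min-1.g-1 to 550 mL.min-1.g-1.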

Compound 4, intrinsic clearance in microsomes: 130 mL.min-1.g-1
The estimate for compound 4 lay 1.5-fold (0.19 log units) above the measured number; measured number inside the range.
By their numbers in this assay, from the lowest: compounds 1 and 4 (each within the scatter of the next); then compounds 2 and 3 (each within the scatter of the next).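

Among the compounds shown here, compound 4 is the first here with a hetero atom in the aromatic ring on the amine nitrogen, and in this assay this change gives a 4.1-fold lower number from compound 3 to compound 4 (0.61 log units; beyond the scatter) and a 3.5-fold lower number from compound 2 to compound 4 (0.54 log units; beyond the scatter). Compounds 2 and 3 had tied a chloro on this ring to fast clearance, but compound 4 goes against that link: it keeps a chloro, yet a 1.2-fold higher number from compound 1 to compound 4 (0.07 log units; within the scatter) places it within the scatter of compound 1, which has no chloro. No measurement shown explains this result.

On these data alone, the step from compound 3 to compound 4 brings in the ring nitrogen, removes the fluoro and moves the chloro all at once, so the share of each remains open. Also open, as far as these compounds go, is whether a 4-methoxypyridin-2-yl or a 4-cyanopyridin-2-yl group would give a number like that of compound 4.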